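The compounds below may be only part of what the source reports. "The series", "measured", "known", "first", "only" and "open" are said of these compounds alone.

For the measured compounds named here, in a functional assay on Shh Light II cells (Mus musculus) for inhibition, read by a luciferase reporter (on this read-out lower numbers stand for stronger inhibition and higher numbers for weaker inhibition), compound 1 `O=C(N1CCC(c2nc(-c3ccc4ccccc4n3)no2)CC1)N1CCCc2ccccc21` gives 2300 nM and compound 2 `O=C(NCC1CCC1)N1CCC(c2nc(-c3ccc4ccccc4n3)no2)CC1` gives 410 nM as the lower of the two numbers so far. Compound 3 `CC(=O)N1CCC(NC(=O)N2CCC(c3nc(-c4ccc5ccccc5n4)no3)CC2)CC1` keeps the rest of compound 2 and differs at one place, on the amide-type nitrogen, where 1-acetylpiperidin-4-yl stands in place of cyclobutylmethyl (1-acetylpiperidin-4-yl in place of cyclobutylmethyl on an amide-type nitrogen). Going by the values given here, the one measured step that bears on this (a 5.6-fold lower number from compound 1 to compound 2 (0.75 log units; beyond the scatter)) brought in the cyclobutylmethyl group that now leaves, and it shows that the number responds to a change of group on this side of the carbonyl. Among the compounds with values here, no measured compound carries the 1-acetylpiperidin-4-yl group, so that step gives only a rough size. A modest move to a higher number is expected in this assay and the estimated step is a 1.7-fold higher number from compound 2 to compound 3 (0.23 log units; within the scatter) with wide uncertainty. For compound 3 the estimated value is 700 nM (expected range 200 nM to 2500 nM).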

Compound 3, half-maximal inhibitory concentration: 500 nM
Beside the measured number, compound 3's estimate is 1.4-fold (0.15 log units) above it; the range from low to high includes it.
By their numbers in this assay, from the lowest: compounds 2 and 3 (each within the scatter of the next); then compound 1.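

In this assay, putting 1-acetylpiperidin-4-yl in place of cyclobutylmethyl on the amide-type nitrogen gives a 1.2-fold higher number from compound 2 to compound 3 (0.09 log units; within the scatter) and so no real change, even though the entering group brings a six-membered ring with a hetero atom and a hydrogen-bond acceptor. The comparison with the 1,2,3,4-tetrahydroquinolin-1-yl compound gives a 4.6-fold lower number from compound 1 to compound 3 (0.66 log units; beyond the scatter), so the gain first seen with compound 2 does not depend on cyclobutylmethyl alone. Both (cyclobutylmethyl)amino and (1-acetylpiperidin-4-yl)amino give lower numbers than that group on the carbonyl carbon.

On these data alone, it remains open whether the number would move with a free amine in place of the acetyl group, or with a carboxylic acid or a longer chain at this nitrogen. Nothing measured here explains why these groups give such similar numbers.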